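A few compounds are considered here, and "the series" means these few. Any claim that something is new, unique, unknown or untested is made for them only; others in the source may bear on it.

Measured compounds in a functional assay on A549 cells (Homo sapiens) for cytotoxicity, read by MTT assay, with a stated time of 72 h; on this read-out lower numbers stand for stronger inhibition and higher numbers for weaker inhibition:
compound 1, `CNC(=O)c1cc(Oc2ccc(NC(=O)c3nccc(-c4ccc(OC)cc4)n3)cc2)ccn1`, 11100 nM;
compound 3, `CNC(=O)c1cc(Oc2ccc(NC(=O)c3nccc(-c4ccc(OC)cc4)n3)cc2F)ccn1`, 16600 nM.
Compound 2, `CNC(=O)c1cc(Oc2ccc(NC(=O)c3cc(-c4ccc(C)cc4)ncn3)cc2)ccn1`, gives only the limit of > 100000 nM in this assay.

Going by the values given here, compound 1 stands lowest of the two numbers, yet the only measured step, a 1.5-fold higher number from compound 1 to compound 3 (0.17 log units; within the scatter), stays within the scatter. Compound 4, `CNC(=O)c1cc(Oc2ccc(NC(=O)c3nccc(-c4ccc(C)cc4)n3)cc2)ccn1`, differs from compound 1 by methyl in place of methoxy on an aromatic carbon. Among the compounds with values here, no measured step covers this change directly; the nearest pointer is compound 2, which also carries a 4-methylphenyl group and in this assay sits at the limit of > 100000 nM in this assay, at which 1 of the 3 values shown sits. In this assay the step of a 1.6-fold higher number from compound 1 to compound 4 (0.21 log units; within the scatter) is therefore expected to be modest and toward a higher number, with wide uncertainty. Compound 4 is estimated at 18000 nM, between 6000 nM and 70000 nM.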

Compound 4, half-maximal inhibitory concentration: 28400 nM
Compound 4: the middle estimate sits 1.6-fold (0.20 log units) below what was measured, and the stated range covers the measured number.
By their numbers in this assay, from the lowest: compounds 1, 3 and 4 (each within the scatter of the next, the first and the last beyond it). At a limit, above all of these: compound 2.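

Going from 4-methoxyphenyl to 4-methylphenyl, para to a large group, gives a 2.6-fold higher number from compound 1 to compound 4 (0.41 log units; beyond the scatter) in this assay. This is the first single change shown that lies beyond the scatter, whereas the fluoro change gave a 1.5-fold higher number from compound 1 to compound 3 (0.17 log units; within the scatter). Compound 2 also carries the 4-methylphenyl group but gives no number, only a limit: the limit of > 100000 nM in this assay, at which 1 of the 4 values shown sits.

Going by these compounds, it remains open whether a hydroxyl, an amine or a longer chain such as ethoxy at this place would stay close to compound 1. Also open, on these data alone, is whether the fluoro change would behave the same way on compound 4.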